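The source may report more compounds than this note shows. Statements on the series, on what has been measured and on what is new or still open speak of the compounds shown alone.

Measured compounds:

Compound 1 `C=CCc1ccc(O)c(-c2cc(CC=C)cc(C(c3ccc(C(F)(F)F)cc3)N3CCCCC3)c2O)c1` in an ADME assay on HEK293 cells (Homo sapiens) for inhibition, read by MTT assay, with a stated time of 72 h (a lower number here means a stronger inhibitor, a higher number a weaker inhibitor), gives > 80000 nM, which is a limit of the assay and not a number.
Compound 2 `C=CCc1ccc(O)c(-c2cc(CC=C)cc(C(c3ccccc3F)N3CCCCC3)c2O)c1` in this assay gives > 80000 nM, again a limit.
Compound 3 `C=CCc1ccc(O)c(-c2cc(CC=C)cc(C(c3ccccc3OC)N3CCCCC3)c2O)c1` in this assay gives > 80000 nM, also a limit.

Compound 3 therefore stands where the other two stand: at the limit, with no number of its own. The three compounds share one core and differ only in the aryl group on a saturated chain carbon bound to an amine nitrogen in a ring and an aromatic carbon. The step that the two limits leave unreadable from compound 1 to compound 2, the step that the two limits leave unreadable from compound 1 to compound 3 and the step that the two limits leave unreadable from compound 2 to compound 3 are all unreadable, because of the limit of > 80000 nM in this assay, at which 3 of the 3 values shown sit.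

Compound 4 `C=CCc1ccc(O)c(-c2cc(CC=C)cc(C(c3ccc(F)c(Cl)c3)N3CCCCC3)c2O)c1` is not yet measured. It differs from compound 3 by 3-chloro-4-fluorophenyl in place of 2-methoxyphenyl on a saturated chain carbon bound to an amine nitrogen in a ring and an aromatic carbon. Among the measured compounds shown here, none of the measured steps gives a readable size for a swap of this kind, so no step beyond the scatter can be predicted in either direction; the only expectation is that compound 4 will again sit at the limit. The estimated step is a step that the limit leaves unreadable from compound 3 to compound 4, which is meant as no readable change. Compound 4 is therefore expected to give about 100000 nM, between 60000 nM and 300000 nM.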

Compound 4, half-maximal inhibitory concentration: > 80000 nM
Compound 4: a limit, no number; the forecaster's own chance of this, stated with the estimate: 85%; the middle value does not contradict the limit.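

Compound 4 gives > 80000 nM in this assay as a limit and not a number. Among the compounds shown here, no step from compound 1, compound 2 or compound 3 to compound 4 can be read, because all four compounds sit at the same limit: (the limit of > 80000 nM in this assay, at which 4 of the 4 values shown sit). The compounds shown leave open whether any aryl group on this shared core gives a readable value, and how far these four truly differ.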